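The source may hold more compounds than are shown below. What is called first, only, known or untested is meant among the compounds shown, and "the series" means these compounds.

Measured compounds:
compound 1, `COc1c(Cl)ccc2c1CCC2c1ncc[nH]1` — > 10000 nM
compound 2, `c1cc(-c2nccs2)c2c(c1)C(c1ncc[nH]1)CC2` — 3190 nM
compound 3, `Cc1ccc2c(c1NS(C)(=O)=O)CCC2c1ncc[nH]1` — > 10000 nM

All three were tested in a functional assay on CHO cells for agonist activity at Alpha-1D adrenergic receptor (Homo sapiens), read by FLIPR and calcium flux; on this read-out higher numbers stand for an effect only at larger amounts of compound and lower numbers for an effect already at smaller amounts. For compound 1 the reading of > 10000 nM is a limit of the assay, not a number. For compound 3 the reading of > 10000 nM is likewise a limit. Among the compounds with values here, compound 2, with 3190 nM, is thus the only compound of the three that returns an actual number in this assay; the other two sit at the limit of > 10000 nM in this assay, at which 2 of the 3 values shown sit, so no step between measured compounds can be drawn from these data.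

Compound 4, `Cn1cc(-c2cccc3c2CCC3c2ncc[nH]2)cn1`, has not yet been tested in this assay. It differs from compound 2 in one place: 1-methyl-1H-pyrazol-4-yl in place of 1,3-thiazol-2-yl on an aromatic carbon

Within the data shown here, with no measured step to lean on, the account can only say what the three readings show: one number and two limits. The expected step from compound 2 to compound 4 is therefore uncertain in direction, and a shift either way beyond the usual scatter would not be surprising. The estimate for compound 4 in this assay is 5000 nM, within a range from 1500 nM to 15000 nM, which corresponds to an expected step of a 1.6-fold higher number from compound 2 to compound 4 (0.20 log units; within the scatter).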

Compound 4, half-maximal effective concentration: > 10000 nM
Compound 4: no number, only a limit; the forecaster's own chance of this, stated with the estimate: 40%; at least 2.0-fold (0.30 log units) between middle value and limit.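

In this assay compound 4 gives > 10000 nM, which is a limit of the assay and not a number. Within the data shown here, this yields the first step that can be read at this position, on an aromatic carbon of a six-membered aromatic ring of carbon only, ortho to a fused ring: an at least 3.1-fold higher number from compound 2 to compound 4 (0.49 log units; beyond the scatter), for 1-methyl-1H-pyrazol-4-yl in place of 1,3-thiazol-2-yl, although both groups are five-membered aromatic rings with 2 hetero atoms and have the same counts of hydrogen-bond donors and acceptors, so these shared counts do not by themselves keep the reading of compound 2 in this pair. The step is bounded on one side only, and compound 2 stays the only compound shown with an actual number: the limit of > 10000 nM in this assay, at which 3 of the 4 values shown sit.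

The compounds shown leave open how far past the limit the true reading of compound 4 lies, and with it the full size of the step. They also leave open whether an amine or a carboxylic acid on this aromatic carbon would give a lower number than compound 2 does in this assay.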